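The compounds below may be only part of what the source reports. "The series", "measured", "known", "first", "only" and "open" are said of these compounds alone.

Measured compounds:
compound 1 `COc1ccc(-n2ncnc2-c2cc(OC)c(OC)c(OC)c2)cc1` — > 10000 nM
compound 2 `CCOc1ccc(-c2ncnn2-c2cc(OC)c(OC)c(OC)c2)cc1` — 15 nM

Compound 1 is read in a functional assay on HeLa cells (Homo sapiens) for antiproliferative activity, read by MTT assay, with a stated time of 72 h; on this read-out lower numbers stand for stronger inhibition and higher numbers for weaker inhibition. For compound 1 only a limit is reported, (the limit of > 10000 nM in this assay, at which 1 of the 2 values shown sits), not a number. Compound 2 differs from compound 1 in several places; in this assay compound 2 gives 15 nM. Compound 3 `COc1cc(-c2ncnn2-c2ccc(N)cc2)cc(OC)c1OC` is not yet measured; it differs from compound 1 by amino in place of methoxy on an aromatic carbon. Among the measured compounds shown here, with no measured step of this kind to lean on, compound 3 is expected to move toward stronger inhibition by an at least 3.3-fold lower number from compound 1 to compound 3 (0.52 log units; beyond the scatter), beyond the usual scatter, but with wide uncertainty. Compound 3 is therefore estimated at 3000 nM, between 300 nM and 20000 nM.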

Compound 3, half-maximal inhibitory concentration: > 10000 nM
Compound 3 gave a limit, no number; the forecaster's own chance of this, stated with the estimate: 40%; at least 3.3-fold (0.52 log units) between middle value and limit.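

In this assay compound 1 and compound 3 both stop at a limit, not a number, so no step between them can be read: the limit of > 10000 nM in this assay, at which 2 of the 3 values shown sit.

The compounds shown leave open whether amino in place of methoxy changes the activity at all.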